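A few compounds are considered here, and "the series" means these few. Any claim that something is new, unique, unknown or untested is made for them only; others in the source may bear on it.

Measured in a functional assay on K562 cells (Homo sapiens) for inhibition, read by MTT assay, with a stated time of 72 h, tested at 10 uM; on this read-out higher numbers stand for more inhibition at the one concentration tested (going by the name of the read-out) and lower numbers for less inhibition:
compound 1, `CCOC(=O)C1=C(Nc2ccccc2)S/C(=C\c2ccccc2)C1=O`, gives 42.9%
compound 2, `CCOC(=O)C1=C(Nc2ccccc2)S/C(=C\c2ccc(Br)c(O)c2)C1=O`, gives 22%
compound 3, `CCOC(=O)C1=C(Nc2ccccc2)S/C(=C\c2ccc[nH]2)C1=O`, gives 16.2%

Compound 3 stands lowest of the three numbers. Its nearest is compound 2, and the step of a number 5.8 percentage points lower from compound 2 to compound 3 (within the scatter) lies within the usual scatter, so these two compounds cannot be told apart on this read-out. Compound 1 is furthest away: the step of a number 26.7 percentage points lower from compound 1 to compound 3 (beyond the scatter) is beyond the scatter, as is a number 20.9 percentage points lower from compound 1 to compound 2 (beyond the scatter). All three compounds share one core and differ only in the aromatic group on the double-bonded chain carbon bound to a double-bonded ring carbon.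

Compound 4, `CCOC(=O)C1=C(Nc2ccccc2)S/C(=C\c2ccc(C(=O)OCC)[nH]2)C1=O`, keeps the five-membered aromatic ring of compound 3 and differs from it in one place: ethoxycarbonyl in place of hydrogen on an aromatic carbon. For the measured compounds named here, none of the measured steps bears directly on this change; each of them exchanged the whole aromatic group rather than adding a substituent to the ring that compound 3 carries. The measured steps therefore give no guidance on direction or size, and the expectation is a step of a number 1.8 percentage points higher from compound 3 to compound 4 (within the scatter), that is, none beyond the scatter. Compound 4 is accordingly estimated at 18%, within a range from 5% to 38%.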

Compound 4, a percentage reported as inhibition, at one concentration (the size of the read-out at that concentration, not a potency): 18.6%
Estimate against measurement, compound 4: 0.6 percentage points below; low and high end bracket the measured number.
By their numbers in this assay, from the lowest: compounds 3, 4 and 2 (each within the scatter of the next); then compound 1.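

For the compounds shown here, compound 3 carries only hydrogen on this aromatic carbon, so the earlier steps, which exchanged the whole aromatic group, could not show what a substituent on this ring would do. In this assay, ethoxycarbonyl placed on this carbon, next to the ring nitrogen, gives a number 2.4 percentage points higher from compound 3 to compound 4 (within the scatter), so a group of 5 heavy atoms with a carbonyl enters here and the read-out cannot tell the two compounds apart. Nothing in the data shown speaks to the reason for this result.

Going by these compounds, it remains open whether other groups on this carbon would read the same, such as a carboxylic acid in place of the ester, an amine, a methyl or a longer chain, and whether the same holds on the other carbons of this ring. Because every number here comes from one concentration, the compounds shown also leave open how compound 3 and compound 4 would compare across a range of concentrations, where a difference hidden at this single reading might appear.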